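A few compounds are considered here, and "the series" means these few. Any claim that something is new, unique, unknown or untested is made for them only; others in the source may bear on it.

Three compounds share one core. Compound 1 `Nc1scc(-c2ccccc2)c1C(=O)c1ccccc1` gives 48% in a functional assay on CHO cells for agonist activity at adenosine receptor A1 (Homo sapiens), read by fluorescence and ERK phosphorylation, with stated times of 30 min and 1.5 h, tested at 10 uM; on this read-out lower numbers stand for a weaker effect and higher numbers for a stronger effect at the one concentration tested. Compound 2 `Nc1scc(-c2ccc3ccccc3c2)c1C(=O)c1ccccc1` gives 73% in the same assay, and compound 3 `Nc1scc(-c2ccccc2)c1C(=O)c1ccc(Cl)cc1` gives 64%. Compound 3 thus stands second highest of the three numbers, within the scatter of compound 2 and beyond the scatter above compound 1; the step of a number 16 percentage points higher from compound 1 to compound 3 (beyond the scatter) is modest. Compound 4 `Nc1scc(-c2ccc(Br)cc2)c1C(=O)c1ccc(Cl)cc1` carries the change (bromo in place of hydrogen on an aromatic carbon). Among the compounds with values here, the only step that bears on it is the halogen added to compound 1, which gave the modest rise just named, so a rise of similar size is expected, a number 8 percentage points higher from compound 3 to compound 4 (within the scatter). Compound 4 is therefore estimated at 72%, between 55% and 88%.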

Compound 4, a percentage reported as activity, at one concentration (the size of the read-out at that concentration, not a potency): 46%
The estimate for compound 4 lay 26 percentage points above the measured number; the measured number lies below the stated range.
By their numbers in this assay, from the lowest: compounds 4 and 1 (each within the scatter of the next); then compounds 3 and 2 (each within the scatter of the next).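

In this assay, changing phenyl to 4-bromophenyl brings a number 18 percentage points lower from compound 3 to compound 4 (beyond the scatter) and so reverses the direction seen with a number 16 percentage points higher from compound 1 to compound 3 (beyond the scatter) when chloro entered elsewhere on the molecule. A halogen on an aromatic carbon therefore does not raise the number regardless of where it sits. Nothing available accounts for this fall. The compounds shown leave open whether bromo at this place would also lower the number without the chloro of compound 3. They also leave open whether fluoro, methoxy or an amine there would behave as bromo does.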